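The source may report more compounds than this note shows. Statements on the series, on what has been measured and on what is new or still open speak of the compounds shown alone.

Series notes. Compound 1 `Nc1cc(N)c2nc(-c3ccccc3)c(Oc3ccc(Cl)c(Cl)c3)nc2c1`, compound 2 `Nc1cc(N)c2nc(-c3ccccc3)c(NCc3ccc(Cl)c(Cl)c3)nc2c1` and compound 3 `CCOC(=O)[C@H](CCC(=O)O)NC(=O)c1ccc(Sc2nc3cc(N)cc(N)c3nc2-c2ccccc2)cc1` share one core and are varied at a single position. In a functional assay on OVCAR-4 cells (Homo sapiens) for inhibition, read by sulforhodamine B assay, with a stated time of 48 h (a lower number here means that less compound is tolerated, a higher number that more compound is tolerated), compound 1 gives < 100000 nM, which is a limit of the assay and not a number. Compound 2 likewise gives only a limit, < 100000 nM. Compound 3 also gives a limit, < 100000 nM. Among the measured compounds shown here, compound 1 thus stands where every value so far stands, on (the limit of < 100000 nM in this assay, at which 3 of the 3 values shown sit), and no step between measured compounds can be sized. Compound 4 `Nc1cc(N)c2nc(-c3ccccc3)c(Sc3ccc(F)cc3)nc2c1` differs from compound 1 by (4-fluorophenyl)sulfanyl in place of 3,4-dichlorophenoxy on an aromatic carbon. With all values at a limit, no direction can be read for compound 4; a step within the scatter is the working assumption. Compound 4 is expected to give 30000 nM in this assay, between 5000 nM and 100000 nM. The expected step is a step that the limit leaves unreadable from compound 1 to compound 4.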

Compound 4, concentration lethal to 50% of the cells: < 100000 nM
Compound 4 was reported as a limit; the forecaster's own chance of this, stated with the estimate: 60%; the middle value does not contradict the limit.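

Compound 4 gives < 100000 nM, which is a limit and not a number, so no step from compound 1 to compound 4 can be read: the limit of < 100000 nM in this assay, at which 4 of the 4 values shown sit.

On these data alone, whether (4-fluorophenyl)sulfanyl and 3,4-dichlorophenoxy differ in effect on the shared core stays open.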